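Moving the chlorine around the phenyl ring

A few compounds are considered here, and "the series" means these few. Any claim that something is new, unique, unknown or untested is made for them only; others in the source may bear on it.

Measured so far:
- compound 1, `O=[N+]([O-])c1ccc(N/C(=N\O)c2ccccc2Cl)c2nonc12`: 135 nM
- compound 2, `O=[N+]([O-])c1ccc(N/C(=N\O)c2ccccc2Br)c2nonc12`: 80 nM
- compound 3, `O=[N+]([O-])c1ccc(N/C(=N\O)c2ccc(F)cc2)c2nonc12`: 100 nM

In an assay on isolated protein for inhibition of Indoleamine 2,3-dioxygenase 1 (Homo sapiens), read by spectrophotometry, with a stated time of 1 h (a lower number here means a stronger inhibitor, a higher number a weaker inhibitor), compound 1 gives 135 nM. Its number is the largest of the three, yet the other two compounds lie within the scatter of it, so the three cannot be told apart with confidence.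

Compound 4, `O=[N+]([O-])c1ccc(N/C(=N\O)c2ccc(Cl)cc2)c2nonc12`, has not yet been measured. It differs from compound 1 in one place: 4-chlorophenyl in place of 2-chlorophenyl on a carbon with a double bond to nitrogen. The atoms are the same; only the position of the chlorine on the phenyl ring changes.

Among the measured compounds shown here, two measured steps bear on this. Replacing the 2-chlorophenyl of compound 1 with a 4-fluorophenyl gave a 1.4-fold lower number from compound 1 to compound 3 (0.13 log units; within the scatter), and swapping the chlorine for bromine gave a 1.7-fold lower number from compound 1 to compound 2 (0.23 log units; within the scatter). Both steps are small, and neither rises above the scatter. Compound 4 keeps the chlorine but moves it to the position that the fluorine holds in compound 3, so no step beyond the scatter is expected in this assay in either direction.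

Compound 4 is therefore expected to give 100 nM, within a range of 40 nM to 250 nM, which corresponds to an estimated 1.4-fold lower number from compound 1 to compound 4 (0.13 log units; within the scatter).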

Compound 4, half-maximal inhibitory concentration: 113 nM
Compound 4: middle estimate off by 1.1-fold (0.05 log units), on the low side, within the range that was stated.
By their numbers in this assay, from the lowest: compounds 2, 3, 4 and 1 (each within the scatter of the next).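

In this assay, moving the chlorine from 2-chlorophenyl to 4-chlorophenyl keeps the same atoms and gives (a 1.2-fold lower number from compound 1 to compound 4 (0.08 log units; within the scatter)), so for chlorine this change of position on the phenyl ring cannot be told from the scatter. The earlier step to compound 3 changed the halogen and its position together, whereas the new compound separates the two: chloro in place of fluoro on the same aromatic carbon gives (a 1.1-fold higher number from compound 3 to compound 4 (0.05 log units; within the scatter)), and 4-chlorophenyl in place of 2-bromophenyl gives (a 1.4-fold higher number from compound 2 to compound 4 (0.15 log units; within the scatter)), and both also stay within the scatter. With these small steps, all four compounds remain indistinguishable in this assay, and no measurement is available that could explain this result.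

Each compound shown carries a single halogen on the phenyl ring, so it remains open whether a methoxy group, an amine or a carboxylic acid at the same place on that ring would leave the number as little changed. A plain phenyl ring with no halogen, or a longer carbon chain in place of the halogen, would show whether this part of the molecule can tolerate larger changes.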